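Same Methyl Group, Different Place, Different Expectation

The source may report more compounds than this note shows. Statements on the series, on what has been measured and on what is new or still open speak of the compounds shown alone.

Compound 1 `COC(=O)N(C)CC#CCN1CCCC1`, compound 2 `COC(=O)N(C)CC#CCn1cncc1C` and compound 3 `COC(=O)N(C)C(C)C#CCn1cncc1C` have been measured; compound 4 `CCOC(=O)N(C)CC#CCN1CCCC1` has not. In a functional assay on the whole organism for agonist activity, with Mus musculus as the target (a higher number here means that more compound is needed for the effect, a lower number that less compound is needed), compound 1 gives 1.4 mg/kg, compound 2 gives 4.5 mg/kg and compound 3 gives 97 mg/kg. How the cores of compound 1 and compound 2 differ is not broken down here. Going by the values given here, the one single-point change measured so far is methyl in place of hydrogen on a saturated chain carbon bound to an amide-type nitrogen and a triple-bonded carbon, and it made a large step: a 22-fold higher number from compound 2 to compound 3 (1.33 log units; beyond the scatter). Compound 4 differs from compound 1 by methyl in place of hydrogen on a saturated chain carbon bound to an oxygen next to a carbonyl group. This is the same kind of change as from compound 2 to compound 3, but not the same change: there the methyl enters on a saturated chain carbon bound to an amide-type nitrogen and a triple-bonded carbon, here on a saturated chain carbon bound to an oxygen next to a carbonyl group. The large loss seen in the measured step therefore cannot simply be carried over. Among the compounds with values here, for compound 4 a small step is expected, a 1.4-fold higher number from compound 1 to compound 4 (0.15 log units; within the scatter), resting on compound 1 giving 1.4 mg/kg and on the methyl entering at a place for which no measured example exists. Compound 4 is estimated at 2 mg/kg, between 0.7 mg/kg and 6 mg/kg.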

Compound 4, dose for half-maximal effect: 66 mg/kg
Compound 4: middle estimate off by 33-fold (1.52 log units), on the low side, outside the stated range (above it).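

In this assay, methyl in place of hydrogen on a saturated chain carbon bound to an oxygen next to a carbonyl group gave a 47-fold higher number from compound 1 to compound 4 (1.67 log units; beyond the scatter), so this second methyl step is also large. Set beside the earlier step, its size cannot be told apart from that one: the same change on two cores in this assay, a 22-fold higher number (1.33 log units; beyond the scatter) from compound 2 to compound 3 and a 47-fold higher number (1.67 log units; beyond the scatter) from compound 1 to compound 4, 2.2-fold (0.34 log units) apart, within the scatter of two such steps. In these two pairs, then, a single added methyl raised the dose needed by a similar large amount, even though it entered at a different place on each core, but two pairs do not show that the loss would carry over to any further core, and they do not explain it.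

The compounds shown leave open how a longer chain such as propoxy, or an amine, would fare in place of the methoxy group. They also leave open what the change from methoxycarbonyl to ethoxycarbonyl would do on the core of compound 2.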